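Changing the ether side chain of an agonist series

This account rests on a few compounds, and the source may have more. Where it says the series, first, only, none or still open, it means among the compounds named here.

Of the compounds shown here, three sharing one core have been tested in a functional assay on HEK293 cells for agonist activity at G-protein coupled receptor 39 (Homo sapiens), read by scintillation proximity assay and inositol phosphate accumulation, with a stated time of 75 min, in the presence of a further agent that is not named here; on this read-out lower numbers stand for an effect already at smaller amounts and higher numbers for an effect only at larger amounts of compound. Compound 1 `Cc1nn(-c2ncnc3nc[nH]c23)c2c1C(OCC(=O)c1ccc(F)cc1)CC(=O)N2` gives 3 nM and has the lowest number of the three, yet it lies within the usual scatter of both compound 2 `Cc1nn(-c2ncnc3nc[nH]c23)c2c1C(C(=O)NCc1ccc(F)cc1)CC(=O)N2` with 4 nM and compound 3 `CCC(C(=O)NC1CC(=O)Nc2c1c(C)nn2-c1ncnc2nc[nH]c12)c1ccccc1` with 5 nM, so no order among them can be claimed. Compound 4 `Cc1nn(-c2ncnc3nc[nH]c23)c2c1C(OCc1cc(F)cc3c1OCOC3)CC(=O)N2` has not been measured. It differs from compound 1 by a group of 11 heavy atoms (8 carbon, 2 oxygen, 1 fluorine; one six-membered non-aromatic ring with 2 hetero atoms, one six-membered aromatic ring of carbon only) in place of a group of 9 heavy atoms (7 carbon, 1 oxygen, 1 fluorine; one six-membered aromatic ring of carbon only), on a saturated chain carbon bound to an oxygen on a saturated carbon. Going by the values given here, no measured pair shows a change of this kind, so the data give no anchor for its effect. The number for compound 4 is expected to stay close to that of compound 1, with the step of a 2.3-fold higher number from compound 1 to compound 4 (0.37 log units; beyond the scatter) estimated as a small rise in this assay. Compound 4 is estimated at 7 nM, with a range from 2 nM to 30 nM.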

Compound 4, half-maximal effective concentration: 1.5 nM
Compound 4: middle estimate off by 4.7-fold (0.67 log units), on the high side; the whole stated range lies above it.
By their numbers in this assay, from the lowest: compounds 4, 1, 2 and 3 (each within the scatter of the next, the first and the last beyond it).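

In this assay, the step at this saturated chain carbon gives a 2.0-fold lower number from compound 1 to compound 4 (0.30 log units; within the scatter), so the position accepts the loss of the (4-fluorophenyl)carbonyl group and the entry of a group with a six-membered non-aromatic ring without a change beyond the scatter. The carbonyl of compound 1 is therefore not needed here to keep a low nanomolar value. Nothing available explains this result. The compounds shown leave open how an amine or a carboxylic acid on this ether side chain would read, and whether a longer chain would hold the value.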